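This account rests on a few compounds, and the source may have more. Where it says the series, first, only, none or still open, it means among the compounds named here.

Measured so far:
- compound 1, `O=c1ccn(CCN2CCCCC2)c(CO)c1O`: 9.24
- compound 2, `Cn1cc(O)c(=O)cc1CN1CCCCC1`: 8.86
- compound 3, `CCc1c(O)c(=O)ccn1CCN(C)C`: 9.58

In a physicochemical assay for acid dissociation, read by spectrophotometry, compound 1 gives 9.24, the second highest of the three numbers. The nearest value is that of compound 3, which lies higher by a margin beyond the scatter; the furthest is that of compound 2, which lies lower, also beyond the scatter. Compounds 2 and 3 differ from compound 1 in more than one place, so neither pair gives a clean step.

The next compound, compound 4, `Cc1c(O)c(=O)ccn1CCN1CCCCC1`, differs from compound 1 in a single place: hydrogen in place of hydroxy on a saturated chain carbon bound to an aromatic carbon. Of the measured compounds, compound 3 is the one that also carries no hydroxy on its chain, and its value in this assay sits above that of compound 1, although other parts of its structure differ too.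

On that basis the step from compound 1 to compound 4 is expected to be a modest rise, a number 0.26 log units higher from compound 1 to compound 4 (within the scatter), a little beyond the scatter rather than a large shift. Compound 4 is therefore estimated at 9.5 in this assay, with a range from 9.2 to 9.8.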

Compound 4, acid dissociation constant: 9.71
Estimate against measurement, compound 4: 0.21 log units below; the measured number falls inside the stated range.
By their numbers in this assay, from the lowest: compound 2; then compound 1; then compounds 3 and 4 (each within the scatter of the next).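

In this assay, going by these compounds alone, the change from hydroxymethyl to methyl gives a number 0.47 log units higher from compound 1 to compound 4 (beyond the scatter), the first step that can be read in one place. It shows that this position is not silent: hydrogen in place of hydroxy on a saturated chain carbon bound to an aromatic carbon is enough on its own to move the number beyond the scatter, and upward. Compounds 2 and 3 could not show this, as each differs from compound 1 in more than one place, and nothing measured here bears on what lies behind the step.

The compounds shown leave open how this position reads with a methoxymethyl, an aminomethyl or a carboxylic acid in place of the hydroxymethyl, as the series so far holds a single change at this place and gives its direction for that change alone. Within the data shown here, they also leave open whether hydroxymethyl to methyl gives a step of similar size when the chain carrying the ring amine differs, as only one pair of compounds carries this change.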